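Imidazole linker shortened: antiproliferative activity in lung epithelial cells

The compounds below may be only part of what the source reports. "The series", "measured", "known", "first", "only" and "open" are said of these compounds alone.

Measured compounds:
Compound 1 `C=CC(=O)Nc1cccc(Nc2nc(Nc3ccc(OCCn4ccnc4)cc3)ncc2Cl)c1` with 39200 nM
Compound 2 `C=CC(=O)Nc1cccc(Nc2nc(Nc3ccc(OCCn4ccnc4)cc3)ncc2F)c1` with 40000 nM

In an ADME assay on NHBE cells (Homo sapiens) for antiproliferative activity, read by MTT assay, with a stated time of 48 h (on this read-out higher numbers stand for weaker inhibition and lower numbers for stronger inhibition), compound 1 gives 39200 nM, and compound 2 gives 40000 nM. Going by the values given here, the only measured step, a 1.0-fold higher number from compound 1 to compound 2 (0.01 log units; within the scatter), replaces chloro with fluoro on an aromatic carbon and leaves the read-out essentially unchanged. Compound 2 thus stands at the higher of two numbers that cannot be told apart. The next compound, compound 3 `C=CC(=O)Nc1cccc(Nc2nc(Nc3ccc(Cn4ccnc4)cc3)ncc2F)c1`, carries the same fluoro but changes the group on the aromatic ring: (1H-imidazol-1-yl)methyl in place of 2-(1H-imidazol-1-yl)ethoxy on an aromatic carbon, at a position para to a large group. Among the compounds with values here, no measured step touches this part of the structure, so the change from compound 2 to compound 3 has no direct precedent in these two compounds; the measured step bears on a different place and only shows the read-out unmoved there. The size and direction of the step in this assay for compound 3 therefore rest on a guess.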

Compound 3, half-maximal inhibitory concentration: > 40000 nM
Compound 3: only a limit was reported; the forecaster's own chance of this, stated with the estimate: 15%; at least 1.1-fold (0.05 log units) between middle value and limit.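

Up to compound 2 the only measured change was fluoro in place of chloro, so compound 3 is the first to test the group para to a large group. In this assay (1H-imidazol-1-yl)methyl in place of 2-(1H-imidazol-1-yl)ethoxy brings a number no lower from compound 2 to compound 3 (the limit leaves the size open). Compound 3 gives > 40000 nM, which is a limit and not a number. The reading at this position therefore ends at the edge of what the assay reports: the limit of > 40000 nM in this assay, at which 1 of the 3 values shown sits.

The compounds shown leave open how far compound 3 actually lies from compound 2. They also leave open whether a longer chain carrying the imidazole, or an amine in its place, would give a lower number in this assay.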